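The source may hold more compounds than are shown below. What is called first, only, known or untested is meant among the compounds shown, and "the series" means these compounds.

Compound 1 `C#CCn1c(-c2ccc(C(=O)N/N=C/c3cccn3C)cc2)nc2ccccc21` is tested in an assay on cells for inhibition of Amine oxidase [flavin-containing] B (Homo sapiens), read by fluorescence and Amplex Red, with stated times of 30 min and 5 min (a higher number here means a weaker inhibitor, a lower number a stronger inhibitor), and gives 12200 nM there. Among the compounds with values here, of the two numbers known so far in this assay this is the highest; the only measured neighbour is compound 2 `C#CCn1c(-c2ccc(C(=O)N/N=C/c3ccc(O)cc3)cc2)nc2ccccc21`, which in this assay gives 1970 nM. Within the data shown here, the one measured step, a 6.2-fold lower number from compound 1 to compound 2 (0.79 log units; beyond the scatter), swaps the same ring for a hydroxyphenyl carrying its hydroxyl in a different position. The new compound 3 `C#CCn1c(-c2ccc(C(=O)N/N=C/c3cccc(O)c3)cc2)nc2ccccc21` differs from compound 1 in that (3-hydroxyphenyl in place of 1-methyl-1H-pyrrol-2-yl on a carbon with a double bond to nitrogen). Among the measured compounds shown here, the single step bearing on this change is the one from compound 1 to compound 2; it lowered the number by a modest but clearly resolved amount. Whether moving the hydroxyl from the fourth to the third position keeps that gain cannot be read from two compounds, so the expectation is for a step in the same direction, somewhat smaller, and the estimated step is a 3.5-fold lower number from compound 1 to compound 3 (0.54 log units; beyond the scatter). Compound 3 is therefore expected to give about 3500 nM in this assay, within a range from 1200 nM to 10000 nM.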

Compound 3, half-maximal inhibitory concentration: >= 1000000 nM
Compound 3 was reported as a limit; the forecaster's own chance of this, stated with the estimate: 5%; middle value at least 280-fold (2.45 log units) away from the limit.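

In this assay the reading for compound 3 is a limit of the assay and not a number: the limit of >= 1000000 nM in this assay, at which 1 of the 3 values shown sits.

Exchanging 1-methyl-1H-pyrrol-2-yl for 3-hydroxyphenyl gives an at least 81-fold higher number from compound 1 to compound 3 (1.91 log units; beyond the scatter), which runs opposite to the earlier step, a 6.2-fold lower number from compound 1 to compound 2 (0.79 log units; beyond the scatter), so replacing the 1-methyl-1H-pyrrol-2-yl with a hydroxyphenyl does not by itself lower the number. The sharpest comparison is 3-hydroxyphenyl in place of 4-hydroxyphenyl, which gives an at least 500-fold higher number from compound 2 to compound 3 (2.70 log units; beyond the scatter) and shows that, among these three compounds, the place of the hydroxyl on the ring decides the direction of the change, something compounds 1 and 2 alone could not show.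

The compounds shown leave open whether the lower number of compound 2 depends on the hydroxyl itself or on the six-membered ring, a question that an unsubstituted phenyl, a 4-methoxyphenyl or a 4-aminophenyl at this place would help to settle. They also leave open the full size of both new steps, since compound 3 is bounded on one side only, and they do not explain why moving the hydroxyl has so large an effect.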